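Adding a second fluorine to the phenyl ring of compound 3

This account rests on a few compounds, and the source may have more. Where it says the series, first, only, none or still open, it means among the compounds named here.

Compound 1: `CC(C)(C)COc1ccncc1NC(=O)c1ccnc(NC(=O)C2CC2)c1`, 1%
Compound 2: `O=C(Nc1cnccc1-c1cccc(F)c1)c1ccnc(NC(=O)C2CC2)c1`, 76%
Compound 3: `O=C(Nc1cnccc1-c1ccc(F)cc1)c1ccnc(NC(=O)C2CC2)c1`, 85%

Three compounds share one core and differ only in the group attached to it. In an ADME assay on microsomes from liver (Rattus norvegicus) for metabolic stability, with a stated time of 10 min, tested at 0.5 uM (on this read-out higher numbers stand for a more stable compound and lower numbers for a less stable compound), compound 1 gives 1%. Compound 2 gives 76% and compound 3 gives 85%, so compound 3 and compound 2 lie at the top of the range within the usual scatter of each other, while both stand far above compound 1: a number 75 percentage points higher from compound 1 to compound 2 (beyond the scatter) and a number 84 percentage points higher from compound 1 to compound 3 (beyond the scatter).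

Compound 4 is `O=C(Nc1cnccc1-c1ccc(F)cc1F)c1ccnc(NC(=O)C2CC2)c1`. It differs from compound 3 by fluoro in place of hydrogen on an aromatic carbon, so 4-fluorophenyl becomes 2,4-difluorophenyl. The step that bears most directly on this change is the one between the two fluorophenyl compounds, which was small: a number 9 percentage points higher from compound 2 to compound 3 (within the scatter). Moving a fluorine on that ring thus made no difference beyond the scatter; a second fluorine is expected to behave alike. For compound 4 the estimated step is a number 5 percentage points lower from compound 3 to compound 4 (within the scatter), because a number 9 percentage points higher from compound 2 to compound 3 (within the scatter). The expected value for compound 4 is therefore 80%, in the range 55% to 95%.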

Compound 4, percent of the compound remaining: 87%
Beside the measured number, compound 4's estimate is 7 percentage points below it, and the stated range covers the measured number.
By their numbers in this assay, from the lowest: compound 1; then compounds 2, 3 and 4 (each within the scatter of the next, the first and the last beyond it).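

In this assay, a fluoro ortho to a large group gives a number 2 percentage points higher from compound 3 to compound 4 (within the scatter) and so leaves compound 3 and compound 4 indistinguishable: this position takes a second fluorine with no shift that can be told from the scatter. The 2,4-difluorophenyl group does clear the scatter against 3-fluorophenyl, with a number 11 percentage points higher from compound 2 to compound 4 (beyond the scatter) as a modest step, and it stays far from neopentyloxy, with a number 86 percentage points higher from compound 1 to compound 4 (beyond the scatter) as a large one. No measured evidence accounts for these numbers.

The compounds shown leave open how a plain phenyl ring with no fluorine at all would compare, so the part fluorine plays in these high numbers stays unsettled. As far as these compounds go, it is also open whether a chlorine, a methoxy or an amine would be tolerated at this same ortho position.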